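A few compounds are considered here, and "the series" means these few. Any claim that something is new, unique, unknown or untested is made for them only; others in the source may bear on it.

Measured in a functional assay on U-251 cells (Homo sapiens) for inhibition, read by sulforhodamine B assay, with a stated time of 72 h; a higher number here means that more compound is needed for the effect, a lower number that less compound is needed:
Compound 1 `CC(C)(C)c1ccc(C(=O)/C=C/c2ccc([N+](=O)[O-])o2)cc1`: 44500 nM
Compound 2 `O=C(/C=C/c1ccc([N+](=O)[O-])o1)c1ccc(-c2ccccc2)cc1`: 24600 nM
Compound 3 `Cc1cccc(C(=O)/C=C/c2ccc([N+](=O)[O-])o2)c1`: 2300 nM

Compound 3 has the lowest number of the three, and both other values lie beyond the scatter from it. Compound 4 `O=C(/C=C/c1ccc([N+](=O)[O-])o1)c1cccc(Br)c1` carries bromo in place of methyl on an aromatic carbon, meta to a large group: bromo in place of methyl on an aromatic carbon. Among the compounds with values here, the only measured step, a 1.8-fold lower number from compound 1 to compound 2 (0.26 log units; within the scatter), is a different exchange, phenyl in place of tert-butyl, and it stays within the scatter. Within the data shown here, no measured step swaps methyl for bromo, so no shift beyond the scatter in either direction is expected in this assay. The estimated change is a 1.1-fold higher number from compound 3 to compound 4 (0.04 log units; within the scatter). For compound 4 the expected value is 2500 nM, with an estimated range from 900 nM to 7000 nM.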

Compound 4, half-maximal effective concentration: 5800 nM
Compound 4: the middle estimate sits 2.3-fold (0.37 log units) below what was measured, within the range that was stated.
By their numbers in this assay, from the lowest: compound 3; then compound 4; then compounds 2 and 1 (each within the scatter of the next).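

In this assay, bromo in place of methyl on an aromatic carbon, meta to a large group, gives a 2.5-fold higher number from compound 3 to compound 4 (0.40 log units; beyond the scatter). Within the data shown here, this shows that an exchange of one heavy atom at this place can move the number beyond the scatter, which the only earlier step, at a different place, did not show. No measured evidence bears on the reason for this shift. Open, going by these compounds, is how an amine or a methoxy group at this place would compare with methyl and bromo.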